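A few compounds are considered here, and "the series" means these few. Any claim that something is new, unique, unknown or untested is made for them only; others in the source may bear on it.

The series shares one core, seen in compound 1 `C=CC1=C(C(=O)NCc2ccccc2)C(c2ccc(OC)cc2)OC1`, compound 2 `C=CC1=C(C(=O)NCCCCC)C(c2ccc(OC)cc2)OC1` and compound 3 `C=CC1=C(C(=O)NCC(C)C)C(c2ccc(OC)cc2)OC1`; only the group on the amide nitrogen changes. In a functional assay on HeLa cells (Homo sapiens) for cytotoxicity, read by MTT assay, with a stated time of 24 h (a higher number here means a weaker inhibitor, a lower number a stronger inhibitor), compound 1 gives only a limit, > 100000 nM. In this assay compound 2 likewise gives only a limit, > 100000 nM. In this assay compound 3 also gives only a limit, > 100000 nM. Compound 3 therefore stands at the limit, and no order among the three can be read. The steps a step that the two limits leave unreadable from compound 1 to compound 2, a step that the two limits leave unreadable from compound 1 to compound 3 and a step that the two limits leave unreadable from compound 2 to compound 3 are all unreadable, as the limit of > 100000 nM in this assay, at which 3 of the 3 values shown sit, shows.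

Compound 4 `C=CC1=C(C(=O)NCc2ccc(C)cc2)C(c2ccc(OC)cc2)OC1` differs from compound 3 by 4-methylphenyl in place of isopropyl on a saturated chain carbon bound to an amide-type nitrogen. For the measured compounds named here, the closest measured change is phenyl in place of isopropyl at the same place, from compound 3 to compound 1, and both ends sit at the limit, so the steps that bear on the present change give no readable size in either direction. The step that the limit leaves unreadable from compound 3 to compound 4 is expected to stay unreadable against the limit. Compound 4 is expected to give 150000 nM in this assay, with a range from 50000 nM to 500000 nM, most likely reported as a limit again.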

Compound 4, half-maximal inhibitory concentration: 15900 nM
The estimate for compound 4 lay 9.4-fold (0.97 log units) above the measured number; the whole stated range lies above it.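

In this assay, the group on the amide nitrogen now gives a first readable change, with an at least 6.2-fold lower number from compound 3 to compound 4 (0.79 log units; beyond the scatter) and an at least 6.2-fold lower number from compound 2 to compound 4 (0.79 log units; beyond the scatter). The smallest of the three changes is enough to leave the limit: methyl in place of hydrogen on an aromatic carbon gives an at least 6.2-fold lower number from compound 1 to compound 4 (0.79 log units; beyond the scatter). Compound 4 is thus the only compound shown with a measured number, and the rest of the series remains at the limit: the limit of > 100000 nM in this assay, at which 3 of the 4 values shown sit.

On these data alone, whether an ethyl group or a carboxylic acid on the same aromatic carbon would lower the number further stays open. As far as these compounds go, the full size of the three steps also stays open, and the steps among compound 1, compound 2 and compound 3 cannot be read.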